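The compounds below may be only part of what the source reports. "The series", "measured", "known", "first", "only" and "open" are said of these compounds alone.

Compound 1, with structure `COc1ccc(NC(=O)Oc2cc(=O)n(CCCO)c3c2CC(CC=C(C)C)C(C)(C)C3)cc1`, has the lower of the two numbers measured in a functional assay on PANC-1 cells (Homo sapiens) for inhibition, read by MTT assay, with a stated time of 24 h, tested at 10 uM; on this read-out lower numbers stand for less inhibition and higher numbers for more inhibition at the one concentration tested (going by the name of the read-out): compound 1 gives 3.7%, the lowest of the two numbers shown. Its nearest neighbour is compound 2, with structure `CC(C)=CCC1Cc2c(OC(=O)Nc3ccc(F)cc3F)cc(=O)n(CCCO)c2CC1(C)C`, and in this assay compound 2 gives 69.7%. Within the data shown here, the one measured step, a number 66 percentage points higher from compound 1 to compound 2 (beyond the scatter), exchanges the aryl group on the carbamate nitrogen and leaves the rest of the shared core untouched.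

Compound 3, with structure `COc1ccc(NC(=O)Oc2cc(=O)n(CCCO)c3c2CC(C/C=C(\C)CCC=C(C)C)C(C)(C)C3)cc1`, keeps the 4-methoxyphenyl carbamate of compound 1 and instead changes the side chain on the saturated ring of the core: 3-methylbut-2-en-1-yl in place of hydrogen on a saturated chain carbon bound to a double-bonded chain carbon. Among the measured compounds shown here, the step from compound 1 to compound 2 therefore does not bear on this change; it concerns a different part of the molecule, and no measured pair tells how lengthening this chain moves the read-out in this assay. Lacking such a step, the expectation for compound 3 rests on compound 1 alone, and an expected step of a number 4.3 percentage points higher from compound 1 to compound 3 (within the scatter) is estimated, which lies within the scatter. Compound 3 is thus expected to give about 8%, in the range 0% to 30%.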

Compound 3, a percentage reported as inhibition, at one concentration (the size of the read-out at that concentration, not a potency): 64.1%
Compound 3: middle estimate off by 56.1 percentage points, on the low side, outside the stated range (above it).
By their numbers in this assay, from the lowest: compound 1; then compounds 3 and 2 (each within the scatter of the next).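

The side chain, held constant between compound 1 and compound 2, turns out to matter as much in this assay: the change of 3-methylbut-2-en-1-yl to 3,7-dimethylocta-2,6-dien-1-yl gives a number 60.4 percentage points higher from compound 1 to compound 3 (beyond the scatter), with 3-methylbut-2-en-1-yl in place of hydrogen on a saturated chain carbon bound to a double-bonded chain carbon. The 4-methoxyphenyl group on the carbamate nitrogen therefore does not by itself fix the read-out at a low level, since compound 3 keeps that group and gives 64.1%, so compound 1 can be raised by a large step from either of two separate places. Nothing available on these compounds accounts for the size of this step.

Still open, on these data alone, is how the read-out follows the chain itself, for instance with a saturated 3,7-dimethyloctyl chain or a longer 3,7,11-trimethyldodeca-2,6,10-trien-1-yl chain in the same place. The compounds shown also leave open what happens when 3,7-dimethylocta-2,6-dien-1-yl and 2,4-difluorophenyl are carried together on the shared core, and whether the two changes then add up.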